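The source may hold more compounds than are shown below. What is called first, only, known or untested is meant among the compounds shown, and "the series" means these compounds.

Two related compounds have been measured so far in a functional assay on DU-145 cells (Homo sapiens) for inhibition, read by trypan blue exclusion, with a stated time of 96 h (a lower number here means a stronger inhibitor of growth, a higher number a weaker inhibitor of growth), and their values sit apart by more than the usual scatter. Compound 1 `Cc1ccc(S(=O)(=O)/C(=C/c2sccc2C)C(=O)c2ccc(Cl)cc2)cc1` gives 10000 nM there, and compound 2 `COc1ccc(S(=O)(=O)/C(=C/c2ccc(C)s2)C(=O)c2ccc(Cl)cc2)cc1` gives 25000 nM as the higher of the two numbers, which makes it the weaker inhibitor of growth. Compound 3 `Cc1ccc(S(=O)(=O)/C(=C/c2ccc(C)s2)C(=O)c2ccc(Cl)cc2)cc1` is compound 2 with methyl in place of methoxy on an aromatic carbon in a change from 4-methoxyphenyl to 4-methylphenyl. Going by the values given here, no measured pair isolates this change, so its size is uncertain. Compound 1 also carries 4-methylphenyl, and its value of 10000 nM is the only hint, though it differs elsewhere too. A small shift toward a lower number is expected, perhaps not beyond the scatter, and the estimated move is a 1.9-fold lower number from compound 2 to compound 3 (0.28 log units; within the scatter) in this expectation. Compound 3 is expected to give 13000 nM (estimated range 4000 nM to 30000 nM).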

Compound 3, concentration for 50% growth inhibition: 50000 nM
The estimate for compound 3 lay 3.8-fold (0.59 log units) below the measured number; the whole stated range lies below it.
By their numbers in this assay, from the lowest: compound 1; then compounds 2 and 3 (each within the scatter of the next).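

In this assay methyl in place of methoxy on the aromatic carbon gives a 2.0-fold higher number from compound 2 to compound 3 (0.30 log units; within the scatter) and so, for this pair, the two groups cannot be told apart at this position. The other single change carries more weight: 5-methylthiophen-2-yl in place of 3-methylthiophen-2-yl, with 4-methylphenyl present in both compounds, gives a 5.0-fold higher number from compound 1 to compound 3 (0.70 log units; beyond the scatter) and so, in this pair, where the methyl sits on the thiophene matters beyond the scatter. Nothing available explains either step.

At the position on the six-membered ring only methoxy and methyl are shown, so the effect of a hydroxyl group, an amine or a carboxylic acid there remains open. Also open, as far as these compounds go, is whether the 3-methylthiophen-2-yl group would give the same kind of step alongside 4-methoxyphenyl.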